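The source may hold more compounds than are shown below. What is called first, only, known or untested is meant among the compounds shown, and "the series" means these compounds.

Measured in an assay on Sf9 cells for inhibition of protein deacetylase HDAC6 (Homo sapiens), read by fluorescence, with a stated time of 40 min, tested at 100 nM; on this read-out higher numbers stand for more inhibition at the one concentration tested (going by the name of the read-out) and lower numbers for less inhibition:
compound 1, `O=C(NO)c1ccc(NCc2nc(-c3ccc(Br)cc3)nn2-c2ccccc2)cc1`, gives 54.7%
compound 2, `Cc1ccsc1-c1nc(CNc2ccc(C(=O)NO)cc2)n(-c2ccccc2)n1`, gives 72.1%

Of these two numbers compound 2 stands highest; its nearest neighbour is compound 1. Going by the values given here, the only measured step is a number 17.4 percentage points higher from compound 1 to compound 2 (beyond the scatter), which came from putting 3-methylthiophen-2-yl in place of 4-bromophenyl on an aromatic carbon. Compound 3, `Cc1ccc(-c2nc(CNc3ccc(C(=O)NO)cc3)n(-c3ccccc3)n2)o1`, differs from compound 2 in one place: 5-methylfuran-2-yl in place of 3-methylthiophen-2-yl on an aromatic carbon. Among the compounds with values here, no measured step swaps one five-membered ring for another, so the single step offers no direct guide, and the expected change is none beyond the scatter, a number 4.1 percentage points lower from compound 2 to compound 3 (within the scatter). Compound 3 is therefore estimated at 68%, expected between 50% and 85%.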

Compound 3, a percentage reported as inhibition, at one concentration (the size of the read-out at that concentration, not a potency): 60.7%
The estimate for compound 3 lay 7.3 percentage points above the measured number; measured number inside the range.
By their numbers in this assay, from the lowest: compounds 1 and 3 (each within the scatter of the next); then compound 2.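

At this ring carbon, the two five-membered rings are not interchangeable: with the same count of heavy atoms, 5-methylfuran-2-yl in place of 3-methylthiophen-2-yl gives a clear drop (a number 11.4 percentage points lower from compound 2 to compound 3 (beyond the scatter)). Measured against 4-bromophenyl, the furan gives no clear gain (a number 6 percentage points higher from compound 1 to compound 3 (within the scatter)), so the rise seen with the thiophene does not extend to every five-membered ring here. Nothing available explains this difference.

The two rings also carry their methyl at different places, so the ring atom and the methyl position remain tangled. Plain thiophen-2-yl and furan-2-yl, or a ring bearing an amine, remain open.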